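A few compounds are considered here, and "the series" means these few. Any claim that something is new, unique, unknown or untested is made for them only; others in the source may bear on it.

Values in an assay on HEK293 cells for displacement of a labelled ligand from C-X-C chemokine receptor type 3 (Homo sapiens); on this read-out higher numbers stand for weaker inhibition and lower numbers for stronger inhibition:
compound 1 `CN(CC1=CC[C@H]2C[C@@H]1C2(C)C)Cc1ccccc1`: 15800 nM
compound 2 `CN(CC1=CC[C@H]2C[C@@H]1C2(C)C)Cc1ccc(-c2ccccc2)cc1`: 3160 nM
compound 3 `CN(CC1=CC[C@H]2C[C@@H]1C2(C)C)Cc1ccc(-c2ccc(C(F)(F)F)cc2)cc1`: > 316 nM, a limit of the assay, not a number

Compound 2 holds the lowest of the two numbers shown; its nearest neighbour is compound 1, and a 5.0-fold lower number from compound 1 to compound 2 (0.70 log units; beyond the scatter). Compound 3 gives only a limit, (the limit of > 316 nM in this assay, at which 1 of the 3 values shown sits), so a step that the limit leaves unreadable from compound 2 to compound 3.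

Compound 4 `Cc1cccc(-c2ccc(CN(C)CC3=CC[C@H]4C[C@@H]3C4(C)C)cc2)c1` differs from compound 2 by methyl in place of hydrogen on an aromatic carbon. Among the compounds with values here, the only readable step, from compound 1 to compound 2, concerns a different change; the step most like this one, from compound 2 to compound 3, is unreadable. The methyl is expected to shift the number little, a 1.6-fold lower number from compound 2 to compound 4 (0.20 log units; within the scatter), within or near the scatter. Compound 4 is estimated at 2000 nM, between 600 nM and 6000 nM.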

Compound 4, inhibition constant: > 316 nM
Compound 4: no number, only a limit; the forecaster's own chance of this, stated with the estimate: 10%; the middle value lies beyond the limit too.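

Compound 4 gives > 316 nM in this assay, a limit and not a number, and its steps from compound 1 and compound 2 cannot be read. Going by these compounds, how far methyl or trifluoromethyl in place of hydrogen shifts the number of compound 2 stays open.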